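Adding a Methyl on Two Related Cores

This account rests on a few compounds, and the source may have more. Where it says the series, first, only, none or still open, it means among the compounds named here.

Compound 1 `COc1cc2c(Oc3ccc(NC(=O)c4cc(-c5ccccc5)ccn4)cc3F)ccnc2cc1OCCCN1CCN(C)CC1` and compound 2 `COc1cc2c(Oc3ccc(NC(=O)c4cc(-c5ccccc5C)ccn4)cc3F)ccnc2cc1OCCCN1CCN(C)CC1` share one core, while compound 3 `COc1cc2c(Oc3ccc(NC(=O)c4nccc(-c5ccccc5)n4)cc3F)ccnc2cc1OCCCN1CCCCC1` and compound 4 `COc1cc2c(Oc3ccc(NC(=O)c4nccc(-c5ccc(C)cc5)n4)cc3F)ccnc2cc1OCCCN1CCCCC1` share another; the difference between the two cores is not broken down here. In a functional assay on MKN-45 cells (Homo sapiens) for cytotoxicity, read by MTT assay, with a stated time of 72 h (a higher number here means a weaker inhibitor, a lower number a stronger inhibitor), compound 1 gives 150 nM, and compound 2 gives 240 nM. The change between them is methyl in place of hydrogen on an aromatic carbon, and it made a 1.6-fold higher number from compound 1 to compound 2 (0.20 log units; within the scatter). In this assay compound 3 gives 1030 nM, the highest number among the three measured compounds. Compound 4 carries the same kind of change relative to compound 3, namely (methyl in place of hydrogen on an aromatic carbon). The two places differ: in compound 2 the methyl sits ortho to a large group, whereas in compound 4 it sits para to a large group. Because a 1.6-fold higher number from compound 1 to compound 2 (0.20 log units; within the scatter) stayed within the scatter, compound 4 is expected to move little from compound 3. For compound 4 the expected step is a 1.3-fold higher number from compound 3 to compound 4 (0.10 log units; within the scatter). Compound 4 is estimated at 1300 nM in this assay, with a likely range from 600 nM to 3000 nM.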

Compound 4, half-maximal inhibitory concentration: 580 nM
Estimate against measurement, compound 4: 2.2-fold (0.35 log units) above; measured number below the stated range.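

In this assay, adding the methyl gave a 1.8-fold lower number from compound 3 to compound 4 (0.25 log units; within the scatter), so neither single step on its own moved beyond the scatter. Set side by side, however, the two steps do not agree, one going up and the other down: the same change on two cores in this assay, a 1.6-fold higher number (0.20 log units; within the scatter) from compound 1 to compound 2 and a 1.8-fold lower number (0.25 log units; within the scatter) from compound 3 to compound 4, 2.8-fold (0.45 log units) apart, beyond the scatter of two such steps. This shows that the effect of the change on the core of compound 1 did not carry over as a reliable guide to the core of compound 3, but it does not show why, as the two pairs differ both in their core and in where the methyl stands, para to a large group in compound 4 and at a different place in compound 2, and two pairs cannot separate these differences.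

The compounds shown leave open whether a methyl at one and the same place would step alike on both cores. They also leave open whether a methoxy group or a chlorine atom at the place para to the large group would follow the methyl.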